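The source may hold more compounds than are shown below. What is called first, only, known or untested is meant among the compounds shown, and "the series" means these compounds.

Measured compounds:
compound 1, `CCCCCCCCOc1nc(N)nc2c1ncn2/C=C1/CC1(CO)CO`, gives > 20000 nM
compound 2, `Nc1nc(NC2CC2)c2ncn(/C=C3/CC3(CO)CO)c2n1`, gives 71500 nM
compound 3, `CCCCNc1nc(N)nc2c1ncn2/C=C1/CC1(CO)CO`, gives > 20000 nM

In an ADME assay on BCBL1 cells (Homo sapiens) for cytotoxicity, with a stated time of 7 days (a higher number here means that more compound is tolerated, a lower number that less compound is tolerated), compound 1 stands only at > 20000 nM, which is a limit of the assay and not a number. Compound 3 also returns a limit, > 20000 nM. Going by the values given here, compound 2 is the one measured value, 71500 nM. Compound 4, `CCCSc1nc(N)nc2c1ncn2/C=C1/CC1(CO)CO`, differs from compound 1 by propylsulfanyl in place of octyloxy on an aromatic carbon. Among the compounds with values here, the steps that bear on this change are a step that the limit leaves unreadable from compound 1 to compound 2, a step that the two limits leave unreadable from compound 1 to compound 3 and a step that the limit leaves unreadable from compound 2 to compound 3, none of them readable because of the limit of > 20000 nM in this assay, at which 2 of the 3 values shown sit. The writer therefore expects no step beyond the scatter and most likely another limit. Compound 4 is expected at 50000 nM, with a range from 20000 nM to 150000 nM. The expected step is a step that the limit leaves unreadable from compound 1 to compound 4.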

Compound 4, half-maximal cytotoxic concentration: > 20000 nM
Compound 4: only a limit was reported (the forecaster's own chance of this, stated with the estimate: 60%); the middle value lies beyond the limit too.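

Going by these compounds alone, the result for compound 4 is a limit, and no step to it from compound 1, compound 2 or compound 3 can be read: the limit of > 20000 nM in this assay, at which 3 of the 4 values shown sit. In this assay the compounds shown leave open whether propylsulfanyl, octyloxy and butylamino on the shared core differ at all.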